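The source may hold more compounds than are shown below. What is called first, only, known or untested is meant among the compounds shown, and "the series" means these compounds.

Working notes on the series.

Within the data shown here, compound 1 `COc1ccc([C@@H]2C/C(=N/OCc3cn(-c4ccc(C(=O)c5ccccc5)cc4)nn3)c3cc(CC=C(C)C)c(OC)cc3O2)cc1` is the larger of the two measured members. In a functional assay on HCT-116 cells (Homo sapiens) for inhibition, read by sulforhodamine B assay, with a stated time of 48 h, tested at 50 uM (on this read-out higher numbers stand for more inhibition of growth at the one concentration tested and lower numbers for less inhibition of growth), compound 1 gives 52%, the higher of the two numbers shown, though its neighbour lies within the scatter. Compound 2 `COc1ccc([C@@H]2C/C(=N/O)c3cc(CC=C(C)C)c(OC)cc3O2)cc1` carries the free oxime in place of the whole triazolyl-benzoylphenyl side chain, and in this assay compound 2 gives 47%; the two values sit within the scatter of each other, so no order between compound 1 and compound 2 can be read from them.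

Compound 3 `COc1ccc([C@@H]2C/C(=N/OCc3cn(-c4ccc(NC(=O)c5ccccc5)cc4)nn3)c3cc(CC=C(C)C)c(OC)cc3O2)cc1` is the next member, not yet measured. It differs from compound 1 as follows: benzamido in place of benzoyl on an aromatic carbon. Among the measured compounds shown here, no step between measured compounds covers this kind of exchange. Given that removing the entire side chain from compound 1 to reach compound 2 left the read-out within the scatter, the small change to benzamido is expected to give a step of a number 2 percentage points lower from compound 1 to compound 3 (within the scatter) of no size beyond the scatter, in no firm direction. Compound 3 is therefore estimated at 50% in this assay, within a range from 32% to 68%.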

Compound 3, percent growth inhibition at one concentration: 8%
Compound 3: the middle estimate sits 42 percentage points above what was measured, and the stated range ends above it.
By their numbers in this assay, from the lowest: compound 3; then compounds 2 and 1 (each within the scatter of the next).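

The side chain's far end is not indifferent in this assay: benzamido in place of benzoyl, para to a large group, gives a number 44 percentage points lower from compound 1 to compound 3 (beyond the scatter), a large step, although the values of compound 1 and compound 2 lie within the scatter of each other. Read by the counts, the exchange keeps the six-membered aromatic ring and the double bond outside it, and adds one nitrogen and one hydrogen-bond donor. No measurement on hand bears on why the read-out falls at this exchange.

Still open, as far as these compounds go, is whether the step follows the amide hydrogen, the added nitrogen or the changed link as a whole, which a benzamido carrying a methyl group on its nitrogen, or a benzyl group in place of benzoyl, would help to separate. Also open, from the compounds shown here alone, is how a small amine or a carboxylic acid on this same aromatic carbon would read, and with only these values, no trend along the position can be drawn.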